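Compound 1 to compound 4: replacing the imidazolyl group

The source may report more compounds than this note shows. Statements on the series, on what has been measured and on what is new or still open speak of the compounds shown alone.

Compound 1 `Cc1nccn1-c1cnc(NCc2c(F)ccc3c2CCO3)c2cn[nH]c(=O)c12`: 8 mL.min-1.g-1
Compound 2 `Cc1ncccc1-c1cnc(NCc2c(F)ccc3c2CCO3)c2ncc(=O)[nH]c12`: 21 mL.min-1.g-1
Compound 3 `Cc1ncccc1-c1cnc(NCc2c(F)ccc3c2CCO3)c2n[nH]c(=O)n12`: 8 mL.min-1.g-1

All three values come from an ADME assay on microsomes from liver (Homo sapiens) for metabolic stability, read by LC-MS, using NADPH, with stated times of 5 min and 30 min, tested at 1 uM; a lower number here means slower removal, a higher number faster removal of the compound. Compound 1 at 8 mL.min-1.g-1 is level with compound 3 at 8 mL.min-1.g-1, and these two share the lowest number of the three. Compound 2 at 21 mL.min-1.g-1 has a higher number, beyond the scatter.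

Compound 4 `O=C1CCCN1c1cnc(NCc2c(F)ccc3c2CCO3)c2cn[nH]c(=O)c12` keeps the core of compound 1 and carries 2-oxopyrrolidin-1-yl in place of 2-methyl-1H-imidazol-1-yl on an aromatic carbon. Among the compounds with values here, no measured pair in this assay isolates a change at this place, so the size of the step has no direct support. Only a small rise is expected, and it may not exceed the scatter. The expectation rests on the narrow spread of the measured numbers, which reach only as far as compound 2 at 21 mL.min-1.g-1. The expected step is a 1.5-fold higher number from compound 1 to compound 4 (0.18 log units; within the scatter). For compound 4 the estimated value is 12 mL.min-1.g-1, with an expected range of 6 mL.min-1.g-1 to 25 mL.min-1.g-1.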

Compound 4, intrinsic clearance in microsomes: 23 mL.min-1.g-1
The estimate for compound 4 lay 1.9-fold (0.28 log units) below the measured number; the measured number falls inside the stated range.
By their numbers in this assay, from the lowest: compounds 1 and 3 (each within the scatter of the next); then compounds 2 and 4 (each within the scatter of the next).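

Within the series so far, only compound 1 and compound 4 form a pair that differs at this aromatic carbon, and the exchange of 2-methyl-1H-imidazol-1-yl for 2-oxopyrrolidin-1-yl gives a 2.9-fold higher number from compound 1 to compound 4 (0.46 log units; beyond the scatter) in this assay. The position therefore bears on the read-out, even though both groups have the same heavy-atom count and no net charge. The exchange alters several counted features at once: the ring is no longer aromatic, a double bond outside aromatic rings enters, and one hydrogen-bond acceptor is lost, and nothing available explains the step or assigns it to any one of these.

Open, from the compounds shown here alone, is which of these features carries the step; pyrrolidin-1-yl without the carbonyl, or 1H-imidazol-1-yl without the methyl, would separate them at this carbon. Also open, going by these compounds, is whether an open-chain acetamide here would behave like the 2-oxopyrrolidin-1-yl ring.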